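The compounds below may be only part of what the source reports. "The series", "measured", "known", "first", "only" and "open" are said of these compounds alone.

Of the compounds shown here, three with a shared core have been measured, and a fourth is to follow. Compound 1 `O=C(Nc1ccc(OC(F)(F)F)cc1)c1cc(F)ccc1O` gives 850 nM in a functional assay on HL-60 cells (Homo sapiens) for cytotoxicity, read by luminescence and CellTiter-Glo, with a stated time of 3 days; on this read-out higher numbers stand for weaker inhibition and lower numbers for stronger inhibition. Compound 2 `O=C(Nc1ccc(OC(F)(F)F)c(Cl)c1)c1cc(F)ccc1O` gives 550 nM in this assay. Compound 3 `O=C(Nc1cccc(C(F)(F)F)c1)c1cc(F)ccc1O` gives 970 nM in this assay, the highest of the three numbers, though its gaps to compound 1 and to compound 2 are both within the scatter. How the core of compound 3 differs from that of compound 1 is not broken down here.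

The step from compound 1 to compound 2 is chloro in place of hydrogen on an aromatic carbon; it made a 1.5-fold lower number from compound 1 to compound 2 (0.19 log units; within the scatter). Compound 4 `O=C(Nc1ccc(Cl)c(C(F)(F)F)c1)c1cc(F)ccc1O` is to be measured in this assay, and it differs from compound 3 by chloro in place of hydrogen on an aromatic carbon. This is the same kind of change, not the same: in compound 2 the entering group is ortho to a trifluoromethoxy group and meta to a large group, whereas in compound 4 it is ortho to a trifluoromethyl group and para to a large group.

For the measured compounds named here, because the only measured example of this change, a 1.5-fold lower number from compound 1 to compound 2 (0.19 log units; within the scatter), stayed within the scatter, the step from compound 3 to compound 4 is expected to be small as well, about a 1.4-fold lower number from compound 3 to compound 4 (0.14 log units; within the scatter). Compound 4 is accordingly estimated at 700 nM in this assay, with a likely range from 350 nM to 1400 nM.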

Compound 4, half-maximal inhibitory concentration: 600 nM
Beside the measured number, compound 4's estimate is 1.2-fold (0.07 log units) above it, within the range that was stated.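

In this assay, chloro in place of hydrogen on an aromatic carbon gave a 1.6-fold lower number from compound 3 to compound 4 (0.21 log units; within the scatter), and the two available examples of this change agree across two cores: the same change on two cores in this assay, a 1.5-fold lower number (0.19 log units; within the scatter) from compound 1 to compound 2 and a 1.6-fold lower number (0.21 log units; within the scatter) from compound 3 to compound 4, 1.0-fold (0.02 log units) apart, within the scatter of two such steps

Within these two pairs, then, the change carried over from the core of compound 1 to the core of compound 3 with a step of matching size, even though in compound 4 the chloro stands ortho to a trifluoromethyl group and para to a large group. This does not show that chloro really shifts the number, since each step lies within the scatter, and two pairs in a single assay cannot establish that the agreement would hold on any further core in this series.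

The compounds shown leave open whether another group at the place taken by chloro, such as a methoxy group, a nitrile or an amine, would give a step beyond the scatter. They also leave open how the number would respond to a change elsewhere on the shared core, for instance a methoxy group in place of the hydroxyl group or a chloro in place of the fluoro.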